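Replacing the 3,4-dichlorophenyl group of compound 3 with phenyl

The source may hold more compounds than are shown below. What is called first, only, known or untested is meant among the compounds shown, and "the series" means these compounds.

In a functional assay on U-87MG ATCC cells for antiproliferative activity against U-87 MG (Homo sapiens), read by MTT assay, with a stated time of 48 h (a higher number here means a weaker inhibitor, a lower number a stronger inhibitor), compound 1 (`Cc1nc(-c2ccc(Cl)cc2)sc1C(=O)CSc1nc(-c2ccccc2)c(C#N)c(=O)[nH]1`) gives 27600 nM, compound 2 (`COc1ccc(-c2nc(C)c(C(=O)CSc3nc(-c4ccc(Cl)cc4)c(C#N)c(=O)[nH]3)s2)cc1`) gives 45900 nM and compound 3 (`COc1ccc(-c2nc(C)c(C(=O)CSc3nc(-c4ccc(Cl)c(Cl)c4)c(C#N)c(=O)[nH]3)s2)cc1`) gives 68500 nM. Compound 3 thus stands within the scatter of compound 2, and its number is clearly higher than that of compound 1, which places it at the high end of this small set.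

Compound 4 (`COc1ccc(-c2nc(C)c(C(=O)CSc3nc(-c4ccccc4)c(C#N)c(=O)[nH]3)s2)cc1`) has phenyl in place of 3,4-dichlorophenyl on an aromatic carbon. The closest measured evidence is a 1.5-fold higher number from compound 2 to compound 3 (0.17 log units; within the scatter), where chloro replaces hydrogen on this same aromatic group. Compound 1 also carries phenyl there but differs elsewhere in the structure, so its 27600 nM offers only loose support for a lower number. Losing both chloro groups is therefore expected to give only a modest shift toward a lower number in this assay, with no move beyond the scatter. The expected change is a 1.7-fold lower number from compound 3 to compound 4 (0.23 log units; within the scatter). For compound 4 the estimated value is 40000 nM, with an expected range from 20000 nM to 80000 nM.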

Compound 4, half-maximal inhibitory concentration: 57300 nM
Estimate against measurement, compound 4: 1.4-fold (0.16 log units) below; low and high end bracket the measured number.
By their numbers in this assay, from the lowest: compounds 1, 2, 4 and 3 (each within the scatter of the next, the first and the last beyond it).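

In this assay the phenyl group of compound 4 leaves the number within the scatter of both chlorinated partners, with a 1.2-fold lower number from compound 3 to compound 4 (0.08 log units; within the scatter) and a 1.2-fold higher number from compound 2 to compound 4 (0.10 log units; within the scatter) for the loss of one chloro, so the data do not separate these three groups at this position. For the compounds shown here, the only step here beyond the scatter lies at another place: with phenyl held constant at this position, methoxy in place of chloro gives a 2.1-fold higher number from compound 1 to compound 4 (0.32 log units; beyond the scatter) and is modest in size. No measurement available here explains either result.

From the compounds shown here alone, it remains open whether a group unlike chloro on this phenyl ring, such as an amine or a carboxylic acid, would move the number beyond the scatter. Going by these compounds, it is also open whether the methoxy-for-chloro step would be of similar size with 3,4-dichlorophenyl at this position.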